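The compounds below may be only part of what the source reports. "The series", "measured", "known", "first", "only" and "open" are said of these compounds alone.

Measured compounds:
- Compound 1 `Cc1ccc(-c2c(S(=O)(=O)c3ccccc3)cnc3cc(C)nn23)cc1`: in a functional assay on the whole organism for inhibition, with Mus musculus as the target, with a stated time of 3 h, at a dose of 50 mg/kg by the oral route (a lower number here means less inhibition, a higher number more inhibition at the dose given (going by the name of the read-out)), compound 1 gives 23.2%
- Compound 2 `O=S(=O)(c1ccccc1)c1cnc2cc(-c3ccc(Cl)cc3)nn2c1-c1ccc(Br)cc1`: in this assay compound 2 gives 24.8%
- Compound 3 `Cc1ccc(-c2c(S(=O)(=O)c3ccccc3)cnc3c(Br)c(-c4ccccc4)nn23)cc1`: in this assay compound 3 gives 54.8%

Compound 3 stands highest of the three numbers in this assay. Its nearest neighbour is compound 2, whose number is lower by a gap beyond the usual scatter, and compound 1 lies further away still, also beyond the scatter. Among the compounds with values here, compound 3 is therefore the one measured compound that clearly separates itself from the others.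

Compound 4 `Cc1ccc(-c2c(S(=O)(=O)c3ccccc3)cnc3cc(-c4ccccc4)nn23)cc1` has not yet been measured. It differs from compound 3 in one place: hydrogen in place of bromo on an aromatic carbon. Within the data shown here, no pair of measured compounds differs by this change alone, so nothing measured tells how large its effect is. Compound 1 and compound 2, which both carry hydrogen at that place but differ elsewhere as well, sit far below compound 3.

Because compound 3 gives 54.8% while the two hydrogen-bearing compounds sit much lower, a downward step from compound 3 to compound 4 of a number 19.8 percentage points lower from compound 3 to compound 4 (beyond the scatter) is expected in this assay, though with wide uncertainty. Compound 4 is estimated at 35%, within a range from 15% to 55%.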

Compound 4, a percentage reported as inhibition, in the whole organism at one dose (the size of the read-out at that dose, not a potency): 36.4%
Compound 4: middle estimate off by 1.4 percentage points, on the low side, within the range that was stated.
By their numbers in this assay, from the lowest: compounds 1 and 2 (each within the scatter of the next); then compound 4; then compound 3.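

Within the data shown here, earlier, no pair of compounds isolated a single change, but in this assay two changes on the five-membered aromatic ring can now be read alone. Hydrogen in place of bromo gives a number 18.4 percentage points lower from compound 3 to compound 4 (beyond the scatter), so bromo on this aromatic carbon counts for a modest part of the inhibition at the dose given, while a clear part remains without it. At the ring atom that bears a phenyl group in compound 4, phenyl in place of methyl gives a number 13.2 percentage points higher from compound 1 to compound 4 (beyond the scatter), so this neighbouring place matters too, but nothing available explains either step.

From the compounds shown here alone, whether this gain belongs to bromo alone stays open, as fluoro or an amine on the same carbon could do as well, less or more. It is also unknown how a longer chain would compare with methyl and phenyl at the other place.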